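The source may hold more compounds than are shown below. What is called first, only, known or untested is meant among the compounds shown, and "the series" means these compounds.

Compound 2 `CCCn1c(=O)c2nc(-c3cnn(Cc4cccc(F)c4F)c3)[nH]c2n(CCC)c1=O` is a close relative of compound 1 `CCCn1c(=O)c2nc(-c3cnn(Cc4c(F)cccc4F)c3)[nH]c2n(CCC)c1=O`; the two share the same core and differ only in where the fluorines sit on the benzyl group. In an in vitro assay on HEK293 cells for displacement of a labelled ligand from adenosine receptor A2b (Homo sapiens) (a higher number here means a weaker inhibitor, a lower number a stronger inhibitor), compound 1 gives 390 nM, and compound 2 gives 240 nM. Of these two numbers compound 2 has the lower one, but a 1.6-fold lower number from compound 1 to compound 2 (0.21 log units; within the scatter), so on the numbers shown the two compounds cannot be told apart.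

Compound 3 `CCCn1c(=O)c2nc(-c3cnn(Cc4cc(F)ccc4Cl)c3)[nH]c2n(CCC)c1=O` has not yet been measured. It differs from compound 2 by 2-chloro-5-fluorophenyl in place of 2,3-difluorophenyl on a saturated chain carbon bound to an aromatic nitrogen. Going by the values given here, the only measured step that touches this position is the one from compound 1 to compound 2, a change of fluorine pattern on the same ring, and it stayed within the scatter. Swapping a fluorine for a chlorine and moving the second fluorine is a different kind of change, for which no measured step exists, so the single comparable step gives no reason to expect movement beyond the scatter.

Compound 3 is therefore expected at about 260 nM, with a likely range from 100 nM to 700 nM. This estimate means an expected step of a 1.1-fold higher number from compound 2 to compound 3 (0.03 log units; within the scatter), within the scatter.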

Compound 3, inhibition constant: 4800 nM
Beside the measured number, compound 3's estimate is 18-fold (1.27 log units) below it; the measured number lies above the stated range.
By their numbers in this assay, from the lowest: compounds 2 and 1 (each within the scatter of the next); then compound 3.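

The ring on this saturated chain carbon bound to an aromatic nitrogen is not a place where any halogen pattern is tolerated. In this assay, 2-chloro-5-fluorophenyl in place of 2,3-difluorophenyl gives a 20-fold higher number from compound 2 to compound 3 (1.30 log units; beyond the scatter) and, in place of 2,6-difluorophenyl, gives a 12-fold higher number from compound 1 to compound 3 (1.09 log units; beyond the scatter) while the rest of the molecule stays the same. Going by these compounds alone, the earlier step only rearranged two fluorines and stayed within the scatter, so these are the first steps to show that the halogen pattern on this ring can change the number by far more than the scatter, although nothing available shows why this happens.

Compound 3 differs from the other two by a chlorine and by the placing of its fluorine, so these compounds leave open how much of either step belongs to each of those two features. They also leave open how the number would respond to a different group on this ring, such as a methoxy group, or to a plain benzyl group carrying no halogen at all.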